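This account rests on a few compounds, and the source may have more. Where it says the series, first, only, none or still open, it means among the compounds named here.

Working notes on the series. In an in vivo ADME assay on the whole organism (strain Sprague-Dawley) for metabolic stability, with Rattus norvegicus as the target, at a dose of 2 mg/kg by the intravenous route (on this read-out lower numbers stand for a shorter-lived compound and higher numbers for a longer-lived compound), compound 3 `Cc1cnc(C(=O)NC2CC2)cc1-c1cc2cnnc(-c3ccccc3Cl)c2n(C)c1=O` gives 2.73 h; compound 1 `Cc1ccc(C(=O)NC2CC2)cc1-c1cc2cnnc(-c3ccc(F)cc3F)c2n(C)c1=O` gives 3.06 h and compound 2 `Cc1cnc(C(=O)NC2CC2)cc1-c1cc2cnnc(-c3ccccc3C)c2n(C)c1=O` gives 2.15 h, so all three values lie within the scatter of one another and compound 3 cannot be placed apart from either. The step to compound 4 `Cc1cnc(C(=O)NC2CC2)cc1-c1cc2cnnc(-c3ccc(F)cc3C)c2n(C)c1=O` is 4-fluoro-2-methylphenyl in place of 2-chlorophenyl on an aromatic carbon. Going by the values given here, the one measured step that bears on it is a 1.3-fold higher number from compound 2 to compound 3 (0.10 log units; within the scatter), which compound 4 runs backwards while also taking up a fluorine, the only ring substituent of this kind seen in compound 1. Among the compounds with values here, no measured step here exceeds the scatter, so the expected step is a 1.1-fold lower number from compound 3 to compound 4 (0.04 log units; within the scatter). For compound 4 the estimate in this assay is 2.5 h, between 1.5 h and 4.2 h.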

Compound 4, half-life: 3.35 h
Beside the measured number, compound 4's estimate is 1.3-fold (0.13 log units) below it; low and high end bracket the measured number.
By their numbers in this assay, from the lowest: compounds 2, 3, 1 and 4 (each within the scatter of the next).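

In this assay fluoro on this aryl ring can now be read alone, with a 1.6-fold higher number from compound 2 to compound 4 (0.19 log units; within the scatter) for fluoro in place of hydrogen, and a 1.2-fold higher number from compound 3 to compound 4 (0.09 log units; within the scatter) for the full exchange of 2-chlorophenyl for 4-fluoro-2-methylphenyl. Even with two ring substituents changing at once, this position on the shared core shows no step beyond the scatter. No evidence is available that bears on these steps. From the compounds shown here alone, whether an amine or a carboxylic acid on this aryl ring would give a step beyond the scatter stays open, as does whether the fluoro step carries over to other amide groups.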